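The source may hold more compounds than are shown below. What is called first, only, known or untested is meant among the compounds shown, and "the series" means these compounds.

The measured compounds and their values:

Compound 1, `CCCCc1oc2ccccc2c1C(=O)c1ccc(OCC(=O)NC(C)C)cc1`, gives 17500 nM in a functional assay on U-937 cells (Homo sapiens) for antiproliferative activity, read by MTT assay, with a stated time of 24 h; a higher number here means a weaker inhibitor, a lower number a stronger inhibitor.
Compound 2, `CCCCc1oc2ccccc2c1C(=O)c1ccc(OCC(=O)N2CCOCC2)cc1`, gives 45400 nM in this assay.
Compound 3, `CCCCc1oc2ccccc2c1C(=O)c1ccc(OCC(=O)Nc2cccc(OC)c2)cc1`, gives 24200 nM in this assay.

Compound 1 carries the lowest number of the three. The smaller gap from it is a 1.4-fold higher number from compound 1 to compound 3 (0.14 log units; within the scatter), which stays within the scatter; the larger one is a 2.6-fold higher number from compound 1 to compound 2 (0.41 log units; beyond the scatter), a modest step that does go beyond it. Between the other two, a 1.9-fold lower number from compound 2 to compound 3 (0.27 log units; within the scatter) remains within the scatter.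

Compound 4, `CCCCNC(=O)CCCOc1ccc(C(=O)c2c(CCCC)oc3ccccc23)cc1`, differs from compound 1 at the amide end of the side chain: 2-(butylcarbamoyl)ethyl in place of isopropylcarbamoyl on a saturated chain carbon bound to an oxygen on an aromatic ring. Within the data shown here, two measured steps bear on this region, both reworking the group on the carbonyl or its nitrogen: one gave a 2.6-fold higher number from compound 1 to compound 2 (0.41 log units; beyond the scatter), the other 1.4-fold higher number from compound 1 to compound 3 (0.14 log units; within the scatter). Among the measured compounds shown here, neither alters the distance between the aromatic oxygen and the carbonyl, so that part of the change has no measured counterpart. Taken together, they suggest that changes at this end move the number little. Compound 4 is therefore expected to land near compound 1, with a 1.1-fold higher number from compound 1 to compound 4 (0.06 log units; within the scatter), a step not expected to exceed the scatter. The estimate for compound 4 in this assay is 20000 nM, with a range from 8000 nM to 50000 nM.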

Compound 4, half-maximal inhibitory concentration: 24600 nM
Beside the measured number, compound 4's estimate is 1.2-fold (0.09 log units) below it; the measured number falls inside the stated range.
By their numbers in this assay, from the lowest: compounds 1, 3, 4 and 2 (each within the scatter of the next, the first and the last beyond it).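

In this assay, among these compounds, the replacement of isopropylcarbamoyl by 2-(butylcarbamoyl)ethyl, on a saturated chain carbon bound to an oxygen on an aromatic ring, gives a 1.4-fold higher number from compound 1 to compound 4 (0.15 log units; within the scatter) and so shows for the first time that a longer chain between that oxygen and the carbonyl, combined with a butyl group on the amide nitrogen, leaves the number within the scatter of compound 1. The comparisons with the other two amides read a 1.0-fold higher number from compound 3 to compound 4 (0.01 log units; within the scatter) and a 1.8-fold lower number from compound 2 to compound 4 (0.27 log units; within the scatter) and so place compound 4 within the scatter of both, even though compound 1 and compound 2 stand beyond the scatter of each other, which means this change does not separate compound 4 from any of the three. Nothing measured here offers an explanation for these results.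

The compounds shown leave open what each part of the change contributes, as the 3-(butylcarbamoyl)propyl group alters both the chain and the amide substituent at once, and a 3-(isopropylcarbamoyl)propyl or a (butylcarbamoyl)methyl group would be needed to separate the two. They also leave open whether a longer chain still, or a carboxylic acid or an amine in place of the amide, would move the number beyond the scatter.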